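The source may hold more compounds than are shown below. What is called first, only, known or untested is meant among the compounds shown, and "the series" means these compounds.

Among the measured compounds shown here, compound 1 `CN(C)C(=O)N(Cc1ccco1)Cc1cc([N+](=O)[O-])ccc1O` is one of three compounds measured in a functional assay on KB cells (Homo sapiens) for antiproliferative activity, read by MTT assay, with a stated time of 48 h; on this read-out lower numbers stand for stronger inhibition and higher numbers for weaker inhibition; in that assay compound 1 gives 20800 nM. Compound 3 `CN(C)C(=O)N(Cc1ccco1)Cc1cc(Br)ccc1O` differs from it by a single change (bromo in place of nitro on an aromatic carbon), and compound 3 gives 32800 nM, a step of a 1.6-fold higher number from compound 1 to compound 3 (0.20 log units; within the scatter). Compound 2 `CCOC(=O)N1CCC(N(Cc2cc([N+](=O)[O-])ccc2O)C(=O)N(C)C)CC1` carries a different core; how the two cores differ is not broken down here. In this assay compound 2 gives 24200 nM. Compound 4 `CCOC(=O)N1CCC(N(Cc2cc(Br)ccc2O)C(=O)N(C)C)CC1` is not yet measured and is related to compound 2 by the same change, (bromo in place of nitro on an aromatic carbon), made on the same kind of place. Because the step of a 1.6-fold higher number from compound 1 to compound 3 (0.20 log units; within the scatter) stayed within the scatter, the step expected from compound 2 to compound 4 is small, about a 1.6-fold higher number from compound 2 to compound 4 (0.20 log units; within the scatter). Compound 4 is therefore estimated at 38000 nM, between 18000 nM and 80000 nM.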

Compound 4, half-maximal inhibitory concentration: 24600 nM
For compound 4 the middle estimate is 1.5-fold (0.19 log units) above the measured one; measured number inside the range.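

In this assay, bromo in place of nitro gives a 1.0-fold higher number from compound 2 to compound 4 (0.01 log units; within the scatter) on the second core, so the change again makes no clear difference. Set beside the earlier step, the two cores agree as far as these numbers can tell:
the same change on two cores in this assay, a 1.6-fold higher number (0.20 log units; within the scatter) from compound 1 to compound 3 and a 1.0-fold higher number (0.01 log units; within the scatter) from compound 2 to compound 4, 1.6-fold (0.19 log units) apart, within the scatter of two such steps

This shows that, on these two cores, nitro and bromo can be exchanged with no change larger than the scatter, but it does not show the same for any other core or in any other assay. The compounds shown leave open whether a different group in that place, such as an amine, a carboxylic acid or a methoxy group, would shift the number beyond the scatter.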